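Heteroaryl Amides Replacing tert-Butyl on the Amide Nitrogen

This account rests on a few compounds, and the source may have more. Where it says the series, first, only, none or still open, it means among the compounds named here.

Compound 1 `CC(C)[C@H](C(=O)NC(C)(C)C)c1ccc(Cl)cc1` is the starting point of this comparison. In a functional assay on CHO cells for agonist activity at Free fatty acid receptor 2 (Homo sapiens), read by cAMP accumulation (on this read-out lower numbers stand for stronger inhibition and higher numbers for weaker inhibition), compound 1 gives > 100000 nM, which is a limit of the assay rather than a measured number (the limit of > 100000 nM in this assay, at which 1 of the 3 values shown sits). Two measured compounds carry a heteroaryl group in place of the tert-butyl group on the amide nitrogen. Compound 2 `CC(C)[C@H](C(=O)Nc1ccccn1)c1ccc(Cl)cc1`, with pyridin-2-yl, gives 1400 nM in this assay; compound 3 `CC(C)[C@H](C(=O)Nc1cccnn1)c1ccc(Cl)cc1`, with pyridazin-3-yl, gives 2300 nM. The step of an at least 71-fold lower number from compound 1 to compound 2 (1.85 log units; beyond the scatter) and the step of an at least 43-fold lower number from compound 1 to compound 3 (1.63 log units; beyond the scatter) are both large and point the same way, whereas a 1.6-fold higher number from compound 2 to compound 3 (0.22 log units; within the scatter) shows that the two heteroaryl amides cannot be told apart on this read-out.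

Compound 4 `Cc1csc(NC(=O)[C@H](c2ccc(Cl)cc2)C(C)C)n1` has not yet been measured. It differs from compound 1 by 4-methyl-1,3-thiazol-2-yl in place of tert-butyl on an amide-type nitrogen. The two measured steps of an at least 71-fold lower number from compound 1 to compound 2 (1.85 log units; beyond the scatter) and an at least 43-fold lower number from compound 1 to compound 3 (1.63 log units; beyond the scatter) bear directly on this change, as each of them also exchanges the tert-butyl group for a heteroaryl group at this position, and a step of comparable size in the same direction is expected, namely an at least 55-fold lower number from compound 1 to compound 4 (1.74 log units; beyond the scatter). Compound 4 is therefore estimated at 1800 nM in this assay, with a likely range from 350 nM to 9000 nM.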

Compound 4, half-maximal inhibitory concentration: 1400 nM
Estimate against measurement, compound 4: 1.3-fold (0.11 log units) above, within the range that was stated.
By their numbers in this assay, from the lowest: compounds 2, 4 and 3 (each within the scatter of the next). At a limit, above all of these: compound 1.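

At the amide nitrogen, 4-methyl-1,3-thiazol-2-yl gives the same kind of large drop as the two earlier heteroaryl groups, with an at least 71-fold lower number from compound 1 to compound 4 (1.85 log units; beyond the scatter) in this assay, so the gain now also holds for a five-membered aromatic ring with 2 hetero atoms, one of them sulfur. Among the heteroaryl amides, the new group cannot be told apart from the others, with a 1.6-fold lower number from compound 3 to compound 4 (0.22 log units; within the scatter) and no change at the digits printed from compound 2 to compound 4 (within the scatter), so no exchange of one heteroaryl group for another among these three compounds moves the number beyond the scatter. Compound 1 remains a limit of the assay, so the large step from it gives a bound on the size of the change and not an exact size: the limit of > 100000 nM in this assay, at which 1 of the 4 values shown sits.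

The compounds shown leave open whether the drop requires a heteroaryl group at all, as a plain phenyl group and a cyclohexyl group do not appear among them. They also leave open whether any substituent on the heteroaryl ring, such as a carboxylic acid, an amine or a longer chain in place of the methyl group, would move the number beyond the scatter.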